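Iodo to Trifluoromethoxy: What the Next Number May Be

The source may report more compounds than this note shows. Statements on the series, on what has been measured and on what is new or still open speak of the compounds shown alone.

Compound 1, `O=C(Nc1c(C(O)(C(F)(F)F)C(F)(F)F)ccc2ccccc12)c1ccccc1`, gives 44 nM in an assay on LtK cells with ATP-sensitive inward rectifier potassium channel 11 (Homo sapiens) as the target; on this read-out higher numbers stand for an effect only at larger amounts of compound and lower numbers for an effect already at smaller amounts.
Compound 2, `O=C(Nc1c(C(O)(C(F)(F)F)C(F)(F)F)ccc2ccccc12)c1ccc(I)cc1`, gives 154 nM in this assay.
Compound 3, `O=C(Nc1c(C(O)(C(F)(F)F)C(F)(F)F)ccc2ccccc12)c1ccc(OC(F)(F)F)cc1`, has not yet been measured.

Among the two numbers so far, compound 2 stands highest, and its nearest neighbour is compound 1: the only measured step is a 3.5-fold higher number from compound 1 to compound 2 (0.54 log units; beyond the scatter). That step put an iodo group onto the aromatic carbon that compound 1 carries as hydrogen, and it is modest in size.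

Compound 3 differs from compound 2 by trifluoromethoxy in place of iodo on an aromatic carbon. Within the data shown here, the one measured step bears on this only indirectly: it shows that a group on this aromatic carbon raised the number moderately, but no measured pair compares iodo with trifluoromethoxy there. With both compound 2 and compound 3 carrying a group in that place, the expected step of a 1.3-fold lower number from compound 2 to compound 3 (0.11 log units; within the scatter) is small and not beyond the scatter in either direction. Compound 3 is therefore estimated at 120 nM, with a range from 40 nM to 400 nM.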

Compound 3, half-maximal effective concentration: > 10000 nM
Compound 3 gave a limit, no number; the forecaster's own chance of this, stated with the estimate: 5%; middle value at least 83-fold (1.92 log units) from the limit.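

In this assay compound 3 gives a limit of the assay and not a number: the limit of > 10000 nM in this assay, at which 1 of the 3 values shown sits. This shows that the group on this aromatic carbon, para to a large group, matters far more than the earlier pair suggested, since trifluoromethoxy in place of iodo gives an at least 64-fold higher number from compound 2 to compound 3 (1.81 log units; beyond the scatter), while the first step, iodo in place of hydrogen, gave only a 3.5-fold higher number from compound 1 to compound 2 (0.54 log units; beyond the scatter). Measured against hydrogen on the same carbon, trifluoromethoxy gives an at least 220-fold higher number from compound 1 to compound 3 (2.35 log units; beyond the scatter), so among these three compounds the identity of the group counts, and not merely whether a group is present.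

The exchange changes the heavy atoms and adds a hydrogen-bond acceptor, and these three compounds cannot separate which of those differences goes with the loss of a measurable number. As far as these compounds go, how a methoxy, a chloro or an amine would read on this carbon stays open, as does whether trifluoromethoxy would give the same result on another carbon of this ring.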